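Pyridyl to Bromophenyl: Cytotoxicity Outlook for Compound 4

The source may hold more compounds than are shown below. What is called first, only, known or untested is meant among the compounds shown, and "the series" means these compounds.

Measured compounds:
compound 1 `CC1(c2ccc(NC(c3ccncc3)c3nnnn3C(C)(C)C)cc2)NC(=O)c2ccccc2N1`: "not determined" (no result reported)
compound 2 `CC1(c2ccc(Nc3nc(N4CCc5ccccc5C4)nc(N4CCc5ccccc5C4)n3)cc2)NC(=O)c2ccccc2N1`: > 400000 nM
compound 3 `CCCCCNC(c1ccc(C2NC(=O)c3ccccc3N2)cc1)c1nnnn1C(C)(C)C`: "not determined" (no result reported)
compound 4 `CC1(c2ccc(NC(c3ccc(Br)cc3)c3nnnn3C(C)(C)C)cc2)NC(=O)c2ccccc2N1`: not yet measured

Three compounds share a core, and all were screened in an ADME assay on J774.A1 cells (Mus musculus) for cytotoxicity, read by MTT assay, with a stated time of 72 h; on this read-out lower numbers stand for higher toxicity in this test and higher numbers for lower toxicity in this test. Compound 1 has no number of its own there, so its standing can only be read from its neighbours. Compound 3 likewise gave "not determined" (no result reported). Compound 2 reached only a limit of the assay, > 400000 nM, which is not a number. That single limit, (the limit of > 400000 nM in this assay, at which 1 of the 3 values shown sits), is the only result in this assay, and it points to low toxicity for the whole set.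

Compound 4 differs from compound 1 by 4-bromophenyl in place of pyridin-4-yl on a saturated chain carbon bound to an aromatic carbon and a nitrogen on an aromatic ring. Within the data shown here, with no measured step to lean on, the expected change in this assay is none beyond the usual scatter, with compound 4 most likely also ending at the limit. Compound 4 is therefore estimated at 400000 nM, within 100000 nM to 1000000 nM.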

Compound 4, half-maximal cytotoxic concentration: 400000 nM
Compound 4: the middle estimate sits on the measured number at the digits printed; low and high end bracket the measured number.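

In this assay compound 1 reads "not determined" (no result reported) and offers no number to set against compound 4, so no step can be read between the two. The compounds shown leave open whether 4-bromophenyl in place of pyridin-4-yl changes the toxicity read-out at all.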